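The source may hold more compounds than are shown below. What is called first, only, known or untested is meant among the compounds shown, and "the series" means these compounds.

Working notes on the series. In a functional assay on OVCAR-3 cells (Homo sapiens) for cytotoxicity, read by sulforhodamine B assay, with a stated time of 48 h, tested at 100 uM (on this read-out lower numbers stand for a stronger effect and higher numbers for a weaker effect at the one concentration tested), compound 2 `COc1cc(-c2cc(/C=C/C(=O)c3ccc(Cl)c(Cl)c3)[nH]n2)cc(OC)c1OC` gives -30%, the highest of the three numbers recorded. Compound 1 `COc1ccc(-c2cc(/C=C/C(=O)c3ccc(OC)c(OC)c3)[nH]n2)cc1` gives -96% and compound 3 `COc1ccc(-c2cc(/C=C/C(=O)c3ccc(N)cc3)[nH]n2)cc1` gives -85%; both of these lie beyond the scatter from compound 2. Compound 4 `COc1ccc(C(=O)/C=C/c2cc(-c3cc(OC)c(OC)c(OC)c3)n[nH]2)cc1OC` is not yet measured. It differs from compound 2 in one place: 3,4-dimethoxyphenyl in place of 3,4-dichlorophenyl on a carbonyl carbon.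

Among the compounds with values here, no step between measured compounds is available, so the expectation rests on what the values show. Compound 1, which carries a 3,4-dimethoxyphenyl on the carbonyl carbon, gives -96%. The change from compound 2 to compound 4 is therefore expected to give a downward step, a number 42 percentage points lower from compound 2 to compound 4 (beyond the scatter), beyond the scatter. Compound 4 is estimated at -72%, with a range from -98% to -35%.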

Compound 4, a percentage reported as activity, at one concentration (the size of the read-out at that concentration, not a potency): -84%
For compound 4 the middle estimate is 12 percentage points above the measured one; the measured number falls inside the stated range.
By their numbers in this assay, from the lowest: compound 1; then compounds 3 and 4 (each within the scatter of the next); then compound 2.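

On the carbonyl carbon, 3,4-dimethoxyphenyl in place of 3,4-dichlorophenyl moves the read-out in this assay by a large step (a number 54 percentage points lower from compound 2 to compound 4 (beyond the scatter)), toward a stronger effect. Within the data shown here, this is the first direct reading of the position, since the earlier compounds offered no pair differing in one place. Nothing at hand accounts for the size of this step.

One pair cannot tell whether the step follows from the arrival of the methoxy groups or the departure of the chlorines. As far as these compounds go, how an unsubstituted phenyl or a 3,4-dihydroxyphenyl would read on the same carbonyl carbon remains open.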